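A few compounds are considered here, and "the series" means these few. Any claim that something is new, unique, unknown or untested is made for them only; others in the source may bear on it.

Working notes on the series. The shared core is a substituted acrylic chain carrying an aminobenzylamino group, as in compound 1 `C/C=C(\C(=O)O)C(NCc1ccc(N)cc1)C(C)C`, compound 2 `C/C=C(\C(=O)O)C(NCc1ccc(N)cc1)C1CCCCC1` and compound 3 `C/C=C(\C(=O)NCC(=O)O)C(C)NCc1ccc(N)cc1`. In an assay on a protein complex (K562 cells) for inhibition of integrin alpha-5/beta-1 (Homo sapiens), with stated times of 30 min and 1 h (a higher number here means a weaker inhibitor, a lower number a stronger inhibitor), compound 1 gives 9800 nM, compound 2 gives 2100 nM and compound 3 gives 9800 nM. Among the measured compounds shown here, the one single-point step measured so far is a 4.7-fold lower number from compound 1 to compound 2 (0.67 log units; beyond the scatter). Compound 3 stands level with compound 1 at the digits shown, and the two together hold the highest numbers of the three; compound 2 lies a clear step lower.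

Compound 4 `C/C=C(\C(=O)O)C(C)NCc1ccc(N)cc1` is the next member. Going from compound 3 to compound 4 the change is hydroxy in place of (carboxymethyl)amino on a carbonyl carbon. For the measured compounds named here, no measured step concerns this position: the step from compound 1 to compound 2 changes the substituent on the saturated chain carbon, not the carbonyl carbon, so it bears on the new compound only loosely. Compound 4 keeps the methyl of compound 3 on that saturated carbon, a smaller group than either of those in compound 1 or compound 2, whose numbers in this assay fall as the group grows. The expectation is therefore a step of a 1.5-fold higher number from compound 3 to compound 4 (0.18 log units; within the scatter) that does not go beyond the scatter toward lower numbers. Compound 4 is estimated at 15000 nM in this assay, within 5000 nM to 50000 nM.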

Compound 4, half-maximal inhibitory concentration: 19 nM
For compound 4 the middle estimate is 790-fold (2.90 log units) above the measured one, and the stated range ends above it.
By their numbers in this assay, from the lowest: compound 4; then compound 2; then compounds 1 and 3 (each within the scatter of the next).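

In this assay, among the compounds shown here, the carbonyl carbon turns out to be a far stronger lever than the saturated chain carbon: hydroxy in place of (carboxymethyl)amino gives a 520-fold lower number from compound 3 to compound 4 (2.71 log units; beyond the scatter), against a 4.7-fold lower number from compound 1 to compound 2 (0.67 log units; beyond the scatter) for the only earlier step. The result also overturns the reading of the saturated chain carbon drawn from compound 1 and compound 2, where the larger group carried the lower number: with the carboxy group kept, methyl in place of cyclohexyl gives a 110-fold lower number from compound 2 to compound 4 (2.04 log units; beyond the scatter) and methyl in place of isopropyl gives a 520-fold lower number from compound 1 to compound 4 (2.71 log units; beyond the scatter), so the smallest of the three groups has the lowest number, and the order does not follow group size, with compound 4 going against the earlier trend. No measurement at hand accounts for any of these steps.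

On these data alone, how a simple amine or a methoxy group on the carbonyl carbon would compare with hydroxy and with (carboxymethyl)amino remains open. Also open, as far as these compounds go, is whether an ethyl group or a bare hydrogen on the saturated chain carbon would hold the number of compound 4, and how (carboxymethyl)amino behaves alongside isopropyl or cyclohexyl.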